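This account rests on a few compounds, and the source may have more. Where it says the series, first, only, none or still open, it means among the compounds named here.

Measured in a functional assay on MCF7 cells (Homo sapiens) for cytotoxicity, read by MTT assay, with a stated time of 72 h; a higher number here means a weaker inhibitor, a lower number a stronger inhibitor:
- compound 1 `COc1cc2ncnc(Nc3ccc(F)c(Cl)c3)c2cc1NC(=O)/C=C/c1ccc(F)cc1Cl`: "not active" (no number reported)
- compound 2 `COc1ccc(/C=C/C(=O)Nc2cc3c(Nc4ccc(F)c(Cl)c4)ncnc3cc2OC)c(OC)c1`: 36600 nM

Within the data shown here, compound 2 holds the only number, since compound 1 was reported without one, so its standing cannot be ranked against a second value.

Still unmeasured, compound 3 `COc1cc(/C=C/C(=O)Nc2cc3c(Nc4ccc(F)c(Cl)c4)ncnc3cc2OC)cc(OC)c1` has the same atoms as compound 2, joined differently: 3,5-dimethoxyphenyl in place of 2,4-dimethoxyphenyl on a double-bonded chain carbon bound to a double-bonded chain carbon. Here 3,5-dimethoxyphenyl stands in place of 2,4-dimethoxyphenyl on a double-bonded chain carbon bound to a double-bonded chain carbon.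

Among the measured compounds shown here, no measured step is available to calibrate this change. In this assay, no shift beyond the scatter is expected, and no direction is favoured. The estimated step is a 1.2-fold lower number from compound 2 to compound 3 (0.09 log units; within the scatter). A result without a number, as for compound 1, also remains possible. For compound 3, the estimated value is 30000 nM, with an expected range of 10000 nM to 90000 nM.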

Compound 3, half-maximal inhibitory concentration: 38500 nM
Compound 3: the middle estimate sits 1.3-fold (0.11 log units) below what was measured; low and high end bracket the measured number.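

In this assay, among these compounds, 3,5-dimethoxyphenyl in place of 2,4-dimethoxyphenyl on a double-bonded chain carbon bound to a double-bonded chain carbon gives a 1.1-fold higher number from compound 2 to compound 3 (0.02 log units; within the scatter), the first step that can be read. These two arrangements of the same atoms are not separated by this read-out, so this change offers no handle on the number at this place. No measurement in hand accounts for this result.

As far as these compounds go, whether an amine or a carboxylic acid in place of the dimethoxyphenyl group, or a longer chain at this place, would shift the number in this assay stays open. Among the compounds shown here, compound 1 carries no number and differs from the other two compounds in more than one place, so no step to it can be read.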